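The source may report more compounds than this note shows. Statements on the series, on what has been measured and on what is new or still open speak of the compounds shown alone.

Measured compounds so far:
compound 1, `CCN(Cc1ccccc1)C(=O)C1CCN(S(=O)(=O)c2ccc(C(F)(F)F)nc2)CC1` — "not determined" (no result reported)
compound 2, `CCN(Cc1ccc(F)cc1)C(=O)C1CCN(S(=O)(=O)c2ccc3cn[nH]c3c2)CC1` — 55%

Two compounds share a core in which a piperidine amide carries a sulfonyl group on one side and an ethyl-benzyl amide on the other. In a functional assay on CHO cells for positive allosteric modulation of muscarinic acetylcholine receptor M5 (Homo sapiens), read by calcium flux (on this read-out higher numbers stand for larger maximal responses and lower numbers for smaller maximal responses), compound 2 gives 55%, and this is the only number shown; for compound 1 no result was reported, so nothing can be said about how the two compare.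

Compound 3, `CCN(Cc1ccccc1C)C(=O)C1CCN(S(=O)(=O)c2ccc3cn[nH]c3c2)CC1`, has not been measured yet. It keeps the core of compound 2 and changes only the benzyl part:

2-methylphenyl in place of 4-fluorophenyl on a saturated chain carbon bound to an amide-type nitrogen

No step between measured compounds is available, so there is no shown pattern to lean on for this exchange of 2-methylphenyl in place of 4-fluorophenyl. With a single measured value as the only anchor, the expected step of a number 5 percentage points lower from compound 2 to compound 3 (within the scatter) from compound 2 is small, within the usual scatter, with no clear direction. For compound 3 the largest response is therefore estimated at 50%, likely between 30% and 75%.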

Compound 3, largest response reached (reported as percent of maximum), in percent of the reference or control that the assay uses: 103%
Compound 3: the middle estimate sits 53 percentage points below what was measured, outside the stated range (above it).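

In this assay, putting 2-methylphenyl in place of 4-fluorophenyl on a saturated chain carbon bound to an amide-type nitrogen gives a number 48 percentage points higher from compound 2 to compound 3 (beyond the scatter). This shows that the maximal response is sensitive to this position, even with the rest of the molecule unchanged. The counts do not separate the two groups, since each has 7 heavy atoms, one six-membered aromatic ring of carbon only, no hydrogen-bond donors or acceptors and no net charge, so the change in response goes with a difference those counts do not capture.

Nothing available here explains why the response changes so much with this exchange.

The fluorine and the methyl group differ both in identity and in where they sit on the ring, so the compounds shown leave open which of the two matters; 4-methylphenyl and 2-fluorophenyl would pull these apart. Also open, going by these compounds, is whether the higher response would persist with a larger group such as 2-chlorophenyl, or with a propyl chain in place of the ethyl group on the amide nitrogen.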